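Replacing the aryl group on the ring amine nitrogen

A few compounds are considered here, and "the series" means these few. Any claim that something is new, unique, unknown or untested is made for them only; others in the source may bear on it.

Compound 2 `CCCc1nc(-c2ccccc2)c(CNCCN2CCN(c3ccccc3Cl)CC2)o1` gives 60.1% in an assay on HEK293 cells for inhibition of Voltage-dependent T-type calcium channel subunit alpha-1G (Homo sapiens), read by fluorescence, tested at 10 uM (on this read-out lower numbers stand for less inhibition and higher numbers for more inhibition at the one concentration tested (going by the name of the read-out)), and stands second highest of the three numbers measured. Its nearest neighbour is compound 3 `CCCc1nc(-c2ccccc2)c(CNCCCN2CCN(c3ccccc3Cl)CC2)o1`, which gives 64.7%, a gap within the scatter; furthest from it is compound 1 `CCCc1nc(-c2ccccc2)c(CNCCN2CCN(c3ccccc3F)CC2)o1`, which gives 46.5%. Within the data shown here, the one measured step, a number 13.6 percentage points higher from compound 1 to compound 2 (beyond the scatter), is the only one-place change in the set and concerns the halogen on the aromatic carbon, not the aryl group as a whole.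

Compound 4 `CCCc1nc(-c2ccccc2)c(CNCCN2CCN(c3ccc(C(F)(F)F)cc3)CC2)o1` differs from compound 2 by 4-(trifluoromethyl)phenyl in place of 2-chlorophenyl on an amine nitrogen in a ring. Among the measured compounds shown here, no measured step changes the aryl group itself, and compound 3 differs from compound 2 by its chain, so nothing here speaks directly to this exchange. The halogen step shows that this part of the molecule can move the number beyond the scatter, in either direction in principle. A step of a number 5.1 percentage points lower from compound 2 to compound 4 (within the scatter) is therefore expected only as a wide guess, centred near no change. Compound 4 is estimated at 55%, between 30% and 80%.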

Compound 4, a percentage reported as inhibition, at one concentration (the size of the read-out at that concentration, not a potency): 58.7%
Compound 4: middle estimate off by 3.7 percentage points, on the low side; low and high end bracket the measured number.
By their numbers in this assay, from the lowest: compound 1; then compounds 4, 2 and 3 (each within the scatter of the next).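

Exchanging the whole aryl group on the ring amine nitrogen leaves the number in place: this assay shows a number 1.4 percentage points lower from compound 2 to compound 4 (within the scatter), although the group grows and its substituent changes in both kind and ring position. 4-(trifluoromethyl)phenyl and 2-chlorophenyl therefore cannot be told apart at this place, whereas 2-fluorophenyl can be told apart from 4-(trifluoromethyl)phenyl, with a number 12.2 percentage points higher from compound 1 to compound 4 (beyond the scatter), as well as from 2-chlorophenyl. No measurement given here bears on the reason for this result.

Since the exchange changes substituent and ring position at once, the contribution of each remains unresolved. Also open, as far as these compounds go, are how an unsubstituted phenyl or a phenyl bearing a methoxy group or a nitrile would read at this place, and whether 4-(trifluoromethyl)phenyl behaves the same with the longer chain of compound 3.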